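Halogen swap on the phenyl ring of an azetidine sulfonamide

The source may hold more compounds than are shown below. What is called first, only, known or untested is meant among the compounds shown, and "the series" means these compounds.

Compound 1 `O=C(O)C[C@@H](NC(=O)[C@@H]1CCN1S(=O)(=O)c1cc(Cl)cc(Cl)c1)c1ccc(F)cc1`: 3.2 nM
Compound 2 `O=C(O)C[C@@H](NC(=O)[C@@H]1CCN1S(=O)(=O)c1cc(Cl)cc(Cl)c1)c1ccc(OC2CCCC2)cc1`: 0.5 nM
Compound 3 `O=C(O)C[C@@H](NC(=O)[C@@H]1CCN1S(=O)(=O)c1cc(Cl)cc(Cl)c1)c1ccc(Cl)c(F)c1`: 11 nM

Of the compounds shown here, three sharing one core have been measured in an assay on RPMI-8866 cells for inhibition of integrin alpha-4/beta-1 (Homo sapiens); on this read-out higher numbers stand for weaker inhibition and lower numbers for stronger inhibition. Compound 3 stands with the highest number of the three; its nearest neighbour is compound 1, and compound 2 lies furthest from it. The step of a 3.4-fold higher number from compound 1 to compound 3 (0.54 log units; beyond the scatter) shows what the 4-chloro-3-fluorophenyl group costs against the 4-fluorophenyl group, while a 6.4-fold lower number from compound 1 to compound 2 (0.81 log units; beyond the scatter) shows the gain from the cyclopentyloxy group.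

Compound 4 `O=C(O)C[C@@H](NC(=O)[C@@H]1CCN1S(=O)(=O)c1cc(Cl)cc(Cl)c1)c1ccc(Br)cc1` carries the change (4-bromophenyl in place of 4-chloro-3-fluorophenyl on a saturated chain carbon bound to an amide-type nitrogen and a saturated chain carbon). For the measured compounds named here, no measured step covers a bromine at this position, but the step from compound 1 to compound 3 is the one that bears on it, since it runs in the reverse sense: a plain 4-halophenyl group returning in place of the 4-chloro-3-fluorophenyl group. A modest step back toward the number of compound 1 is therefore expected, a 2.8-fold lower number from compound 3 to compound 4 (0.44 log units; beyond the scatter). For compound 4 the estimate in this assay is 4 nM, with a range from 1.5 nM to 12 nM.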

Compound 4, half-maximal inhibitory concentration: 2.1 nM
Compound 4: middle estimate off by 1.9-fold (0.28 log units), on the high side; low and high end bracket the measured number.
By their numbers in this assay, from the lowest: compound 2; then compounds 4 and 1 (each within the scatter of the next); then compound 3.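

The 4-bromophenyl group gives back what the 4-chloro-3-fluorophenyl group had cost, with a 5.2-fold lower number from compound 3 to compound 4 (0.72 log units; beyond the scatter) in this read-out, and it shows that a single halogen on this ring can be exchanged with little effect: a 1.5-fold lower number from compound 1 to compound 4 (0.18 log units; within the scatter) leaves fluoro and bromo on this aromatic carbon indistinguishable. The cyclopentyloxy group stays apart from the bromo group, with a 4.2-fold higher number from compound 2 to compound 4 (0.62 log units; beyond the scatter) on the same aromatic carbon, so the ether in compound 2 remains distinct from both single halogens. Nothing at hand accounts for these differences.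

The compounds shown leave open whether the higher number of compound 3 goes with the chloro group or with the added fluoro group, which a plain 4-chlorophenyl or 3-fluorophenyl group could separate. On these data alone, how a shorter ether such as methoxy, or an amine, would stand on this aromatic carbon also remains open.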